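Ring closure at the chain on the core nitrogen

The compounds below may be only part of what the source reports. "The series", "measured", "known", "first", "only" and "open" are said of these compounds alone.

Three compounds share one core and differ only in the group on the aromatic nitrogen. Compound 1 `Cn1nc(-c2cccnc2)c2ccccc2c1=O` gives 11500 nM in a functional assay (trachea) with Cavia porcellus as the target; a lower number here means a stronger inhibitor, a higher number a weaker inhibitor. Compound 2 `CCCn1nc(-c2cccnc2)c2ccccc2c1=O` gives 3160 nM, and compound 3 `CCCCCCCCn1nc(-c2cccnc2)c2ccccc2c1=O` gives 21900 nM. Compound 2 stands lowest of the three: a 3.6-fold lower number from compound 1 to compound 2 (0.56 log units; beyond the scatter), and a 6.9-fold higher number from compound 2 to compound 3 (0.84 log units; beyond the scatter). The step from compound 1 to compound 3 is a 1.9-fold higher number from compound 1 to compound 3 (0.28 log units; within the scatter).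

Compound 4 `O=c1c2ccccc2c(-c2cccnc2)nn1C1CCCC1` is not yet measured. Relative to compound 2 the change is cyclopentyl in place of propyl on an aromatic nitrogen.

Going by the values given here, two steps bear on this. Lengthening the chain by two carbons gave a 3.6-fold lower number from compound 1 to compound 2 (0.56 log units; beyond the scatter); extending it by a further five gave a 6.9-fold higher number from compound 2 to compound 3 (0.84 log units; beyond the scatter). The cyclopentyl group adds two carbons over propyl but closes them into a ring, a change the series has not sampled. With the gain from compound 1 to compound 2 already spent, and compound 3 showing loss with more carbon, the expected step is a 1.4-fold higher number from compound 2 to compound 4 (0.15 log units; within the scatter), within the scatter or slightly upward. Compound 4 is expected to give 4500 nM, with a range of 1500 nM to 14000 nM.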

Compound 4, half-maximal inhibitory concentration: 2750 nM
Beside the measured number, compound 4's estimate is 1.6-fold (0.21 log units) above it; low and high end bracket the measured number.
By their numbers in this assay, from the lowest: compounds 4 and 2 (each within the scatter of the next); then compounds 1 and 3 (each within the scatter of the next).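

In this assay the closed cyclopentyl ring on the aromatic nitrogen cannot be told apart from the open propyl chain (a 1.1-fold lower number from compound 2 to compound 4 (0.06 log units; within the scatter)), so five carbons held in a ring do not bring the loss seen with the octyl chain of compound 3. The ring stays well clear of that long chain (an 8.0-fold lower number from compound 3 to compound 4 (0.90 log units; beyond the scatter)) and keeps the gain over methyl (a 4.2-fold lower number from compound 1 to compound 4 (0.62 log units; beyond the scatter)), which places compound 4 with compound 2 rather than with compound 1 or compound 3. No measurement at hand explains why ring and chain read alike at this position.

Open, from the compounds shown here alone, is whether ring size matters, as a cyclobutyl or cyclohexyl ring would show, and whether a branched isopropyl group reads like either. Also open, going by these compounds, is how this position responds to an amine or a hydroxyl group on the ring or chain.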